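Anilino returns, now chlorinated, on the chloropurine core

The source may report more compounds than this note shows. Statements on the series, on what has been measured and on what is new or still open speak of the compounds shown alone.

In a functional assay on HepG2 cells (Homo sapiens) for antiproliferative activity, read by CCK-8 assay, with a stated time of 72 h, tested at 8 uM (on this read-out higher numbers stand for a stronger effect at the one concentration tested and lower numbers for a weaker effect), compound 1 `Nc1ccccc1NC(=O)c1ccc(Cn2cnc3c(Nc4ccccc4)nc(Cl)nc32)cc1` gives 74.8%. Compound 3 `CC1CCN(c2nc(Cl)nc3c2ncn3Cc2ccc(C(=O)Nc3ccccc3N)cc2)CC1` gives 65.3%, second highest of the three numbers; the step of a number 9.5 percentage points lower from compound 1 to compound 3 (within the scatter) leaves it within the scatter of compound 1, whereas compound 2 `Nc1ccccc1NC(=O)c1ccc(Cn2cnc3c(Nc4ccc(-c5ccccn5)cc4)nc(Cl)nc32)cc1` gives 41.2%, the step of a number 33.6 percentage points lower from compound 1 to compound 2 (beyond the scatter) being the only large move in the set. Compound 4 `Nc1ccccc1NC(=O)c1ccc(Cn2cnc3c(Nc4cccc(Cl)c4)nc(Cl)nc32)cc1` is not yet measured and differs from compound 3 by (3-chlorophenyl)amino in place of 4-methylpiperidin-1-yl on an aromatic carbon. The step from compound 1 to compound 3 bears directly, since compound 4 brings back an anilino group, now as (3-chlorophenyl)amino; the step to compound 2 shows that adding pyridin-2-yl on an aromatic carbon cost much, so a chloro may also cost something. The expected step is a number 0.7 percentage points higher from compound 3 to compound 4 (within the scatter). Compound 4 is estimated at 66%, with a range from 50% to 80%.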

Compound 4, a percentage reported as inhibition, at one concentration (the size of the read-out at that concentration, not a potency): 66.7%
Beside the measured number, compound 4's estimate is 0.7 percentage points below it; low and high end bracket the measured number.
By their numbers in this assay, from the lowest: compound 2; then compounds 3, 4 and 1 (each within the scatter of the next).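

In this assay this position accepts (3-chlorophenyl)amino as readily as 4-methylpiperidin-1-yl (a number 1.4 percentage points higher from compound 3 to compound 4 (within the scatter)), and the chloro on the anilino ring leaves the number within the scatter (a number 8.1 percentage points lower from compound 1 to compound 4 (within the scatter)). The loss seen with 4-(pyridin-2-yl)phenyl on the nitrogen does not carry over to 3-chlorophenyl (a number 25.5 percentage points higher from compound 2 to compound 4 (beyond the scatter)). No measurement offered here explains these steps. Open, going by these compounds, is whether a morpholine at this position would hold the number. Also open, on these data alone, is how a methoxy group or a carboxylic acid would fare in place of the chloro on the anilino ring.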